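The source may hold more compounds than are shown below. What is called first, only, known or untested is meant among the compounds shown, and "the series" means these compounds.

Compound 1 `ClCc1ccc(Cn2cnc3c(Cl)ncnc32)cc1`: 97700 nM
Compound 2 `ClCc1ccc(Cn2cnc3ncnc(Cl)c32)cc1`: 7760 nM

Both were tested in a functional assay on UACC-257 cells (Homo sapiens) for cytotoxicity, read by sulforhodamine B assay, with a stated time of 48 h; on this read-out lower numbers stand for higher toxicity in this test and higher numbers for lower toxicity in this test. Compound 2 gives the lowest of the two numbers; compound 1 gives the higher one, and the gap between them lies beyond the scatter. Compound 3 `ClCc1ccc(Cn2cnc3nc(Cl)nc(Cl)c32)cc1` has not yet been measured. It differs from compound 2 by chloro in place of hydrogen on an aromatic carbon. Within the data shown here, no measured pair shows a change of this kind, so its size is unknown from the data; a shift no larger than the scatter, in either direction, is expected. Compound 3 is therefore expected to give 6000 nM, within 1500 nM to 25000 nM. The step of a 1.3-fold lower number from compound 2 to compound 3 (0.11 log units; within the scatter) that this estimate means is expected to stay within the usual scatter.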

Compound 3, concentration lethal to 50% of the cells: 34700 nM
For compound 3 the middle estimate is 5.8-fold (0.76 log units) below the measured one; measured number outside the range, above it.
By their numbers in this assay, from the lowest: compound 2; then compound 3; then compound 1.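

In this assay chloro in place of hydrogen on the aromatic carbon between two ring nitrogen atoms gives a 4.5-fold higher number from compound 2 to compound 3 (0.65 log units; beyond the scatter) and so shows that this position is not indifferent to substitution. Here the added chloro goes with lower toxicity in this test, something no earlier pair could show. Nothing available explains this step. On these data alone, whether an amine or a methoxy group at this position would move the number the same way remains open. So does whether the step would hold without the chloro group meta to it.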